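A few compounds are considered here, and "the series" means these few. Any claim that something is new, unique, unknown or untested is made for them only; others in the source may bear on it.

The series rests on a shared core carried by compound 1 `O=C(Nc1cccc(-n2cc(-c3ccncc3)c(-c3ccc(Cl)c(O)c3)n2)c1)Nc1cccc(C(F)(F)F)c1` and compound 2 `COc1cc(-c2nn(-c3cccc(NC(=O)Nc4ccc(Cl)c(C(F)(F)F)c4)c3)cc2-c2ccncc2)ccc1Cl`. In a functional assay on SNB-19 cells (Homo sapiens) for inhibition, read by sulforhodamine B assay, with a stated time of 48 h (on this read-out higher numbers stand for weaker inhibition of growth and lower numbers for stronger inhibition of growth), compound 1 reaches only a limit of the assay, > 32500 nM. In this assay, among the measured compounds shown here, compound 2 gives 9240 nM, the only number among the values shown. The other value shown is a limit (the limit of > 32500 nM in this assay, at which 1 of the 2 values shown sits). From compound 2 the route leads to compound 3 `O=C(Nc1cccc(-n2cc(-c3ccncc3)c(-c3ccc(Cl)c(O)c3)n2)c1)Nc1ccc(Cl)c(C(F)(F)F)c1`, in which a single change is made: hydrogen in place of methyl on an oxygen on an aromatic ring, that is, methoxy to hydroxy, or 4-chloro-3-methoxyphenyl to 4-chloro-3-hydroxyphenyl. For the measured compounds named here, no pair measured in this assay differs in only this place, so the size of the step is open. The step is expected to weaken growth inhibition, a 2.2-fold higher number from compound 2 to compound 3 (0.34 log units; beyond the scatter), because compound 1, which also carries a 4-chloro-3-hydroxyphenyl group, gives > 32500 nM. Compound 3 is therefore estimated at 20000 nM, within 7000 nM to 60000 nM.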

Compound 3, concentration for total growth inhibition: 4860 nM
Compound 3: middle estimate off by 4.1-fold (0.61 log units), on the high side; measured number outside the range, below it.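

In this assay, the change from methoxy to hydroxy on the aromatic ring gives a 1.9-fold lower number from compound 2 to compound 3 (0.28 log units; within the scatter), so at this position the two groups cannot be told apart. With the hydroxy group kept, chloro in place of hydrogen on an aromatic carbon gives an at least 6.6-fold lower number from compound 1 to compound 3 (0.82 log units; beyond the scatter), which places the difference seen here at that chloro and not at the hydroxy. The true size of that step remains unknown, as compound 1 stands at a limit of the assay: the limit of > 32500 nM in this assay, at which 1 of the 3 values shown sits.

As far as these compounds go, whether an ethoxy group or an amine at the place of the hydroxy would leave growth inhibition equally unchanged remains open. So does whether the match between methoxy and hydroxy would hold with a fluoro or a methyl group in place of the chloro on that ring.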